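The source may hold more compounds than are shown below. What is called first, only, known or untested is meant among the compounds shown, and "the series" means these compounds.

Within the data shown here, in an assay on HEK293 cells for displacement of a labelled ligand from prostaglandin D2 receptor 2 (Homo sapiens), read by scintillation counting, in the presence of a further agent that is not named here (on this read-out higher numbers stand for weaker inhibition and lower numbers for stronger inhibition), compound 1 `CCCCNC(=O)c1ccc(Oc2ccc(CC(=O)O)cn2)c(NS(=O)(=O)c2ccc(Cl)cc2Cl)c1` gives 310 nM, while compound 2 `CCCCNC(=O)c1ccc(Oc2ccc(CC(=O)O)nc2)c(NS(=O)(=O)c2ccc(Cl)cc2Cl)c1` gives 10 nM, the lower of the two numbers measured so far. Among the measured compounds shown here, the one measured step, a 31-fold lower number from compound 1 to compound 2 (1.49 log units; beyond the scatter), came from nothing more than a different placement of the ring nitrogen. Compound 3 `CCCCNC(=O)c1ccc(Sc2ccc(CC(=O)O)cc2)c(NS(=O)(=O)c2ccc(Cl)cc2Cl)c1` carries (4-(carboxymethyl)phenyl)sulfanyl in place of (6-(carboxymethyl)pyridin-3-yl)oxy on an aromatic carbon. For the measured compounds named here, no measured step covers this change, which removes the ring nitrogen and exchanges oxygen for sulfur at once. Because a 31-fold lower number from compound 1 to compound 2 (1.49 log units; beyond the scatter) was large, a moderately weaker result is expected, with the estimated step being a 4.0-fold higher number from compound 2 to compound 3 (0.60 log units; beyond the scatter). Compound 3 is therefore expected to give about 40 nM, within roughly 8 nM to 300 nM.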

Compound 3, half-maximal inhibitory concentration: 21 nM
Beside the measured number, compound 3's estimate is 1.9-fold (0.28 log units) above it, within the range that was stated.
By their numbers in this assay, from the lowest: compound 2; then compound 3; then compound 1.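

Swapping in (4-(carboxymethyl)phenyl)sulfanyl changes the ring and the linking atom at once, and gives a 2.1-fold higher number from compound 2 to compound 3 (0.32 log units; beyond the scatter), so a low number at this position needs neither the ring nitrogen nor the oxygen link. The same group gives a 15-fold lower number from compound 1 to compound 3 (1.17 log units; beyond the scatter), which places the carbon-only ring far closer to compound 2 than to compound 1. Nothing measured here explains these differences.

The separate contributions of the sulfur and the ring nitrogen remain unresolved. Also open, as far as these compounds go, is whether an amine in place of the carboxylic acid would keep the number low.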